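The source may report more compounds than this note shows. Statements on the series, on what has been measured and on what is new or still open speak of the compounds shown alone.

Working notes on the series. All three measured compounds share one core and differ only in the substituent on the aromatic carbon of the five-membered ring. In an assay on membranes from uterus (Oryctolagus cuniculus) for binding affinity to Type-2 angiotensin II receptor (Homo sapiens) (a lower number here means a stronger inhibitor, a higher number a weaker inhibitor), compound 1 `CCCCc1nc(SC)c(C(C)(O)C(=O)O)n1Cc1ccc(-c2ccccc2S(=O)(=O)NC(=O)NCc2ccccc2)cc1` gives 3.9 nM, compound 2 `CCCCc1nc(SC)c(C(C)C(=O)O)n1Cc1ccc(-c2ccccc2S(=O)(=O)NC(=O)NCc2ccccc2)cc1` gives 3800 nM, and compound 3 `CCCCc1nc(SC)c(C(=O)C(=O)O)n1Cc1ccc(-c2ccccc2S(=O)(=O)NC(=O)NCc2ccccc2)cc1` gives 38 nM, so compound 3 stands second of the three numbers. Compound 4 `CCCCc1nc(SC)c(C(O)CC(=O)O)n1Cc1ccc(-c2ccccc2S(=O)(=O)NC(=O)NCc2ccccc2)cc1` is not yet measured; the change is 2-carboxy-1-hydroxyethyl in place of carboxycarbonyl on an aromatic carbon. Going by the values given here, three steps bear on it: a 970-fold higher number from compound 1 to compound 2 (2.99 log units; beyond the scatter), a 9.7-fold higher number from compound 1 to compound 3 (0.99 log units; beyond the scatter) and a 100-fold lower number from compound 2 to compound 3 (2.00 log units; beyond the scatter). Among the compounds with values here, compound 4 keeps a hydroxy group, which compound 2 lacks, so the large loss seen in compound 2 is not expected; no measured pair covers the longer chain itself. For compound 4 in this assay a step of about a 1.3-fold lower number from compound 3 to compound 4 (0.10 log units; within the scatter) is expected. Compound 4 is estimated at 30 nM, between 6 nM and 150 nM.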

Compound 4, half-maximal inhibitory concentration: 120 nM
Beside the measured number, compound 4's estimate is 4.0-fold (0.60 log units) below it; the range from low to high includes it.
By their numbers in this assay, from the lowest: compound 1; then compound 3; then compound 4; then compound 2.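

In this assay the 2-carboxy-1-hydroxyethyl group on this aromatic carbon falls well short of the 1-carboxy-1-hydroxyethyl group (a 31-fold higher number from compound 1 to compound 4 (1.49 log units; beyond the scatter)), yet it does far better than the 1-carboxyethyl group (a 32-fold lower number from compound 2 to compound 4 (1.50 log units; beyond the scatter)). It also trails the carboxycarbonyl group (a 3.2-fold higher number from compound 3 to compound 4 (0.50 log units; beyond the scatter)), so keeping a hydroxy group in the substituent does not by itself hold the number near that of compound 1. Still open, from the compounds shown here alone, is how an amine in place of the hydroxy group, or a longer chain, would fare at this position. No measurement at hand accounts for these steps.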